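The source may hold more compounds than are shown below. What is called first, only, known or untested is meant among the compounds shown, and "the series" means these compounds.

Compound 1 `Cc1ccc(/C=C2\CCC/C(=C\c3ccc([N+](=O)[O-])cc3)C2=O)cc1`: in a functional assay on CCRF-CEM cells (Homo sapiens) for cytotoxicity, with a stated time of 72 h (a higher number here means a weaker inhibitor, a lower number a stronger inhibitor), compound 1 gives 8530 nM.
Compound 2 `COc1cc(/C=C2\CCC/C(=C\c3ccccc3[N+](=O)[O-])C2=O)cc(OC)c1OC`: in this assay compound 2 gives 402 nM.
Compound 3 `O=C1CCCC/C1=C\c1ccccc1[N+](=O)[O-]`: in this assay compound 3 gives 36400 nM.

Of the three measured compounds, compound 1 stands second highest. The gap from compound 1 to compound 3 lies beyond the usual scatter, as does the larger gap from compound 1 down to compound 2, so compound 2 is the strongest inhibitor of the three and compound 3 the weakest. These three compounds differ from one another in more than one place, so none of the gaps can be tied to a single structural change.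

Compound 4 `O=C1/C(=C/c2ccc(Cl)cc2)CCC/C1=C\c1ccc([N+](=O)[O-])cc1` has not yet been measured. It differs from compound 1 in one place: chloro in place of methyl on an aromatic carbon. Within the data shown here, the shared core of compound 1 and compound 4 is unchanged, and no measured pair shows what this exchange of a methyl for a chloro does in this assay. With nothing to go on beyond the single-point change, the step from compound 1 to compound 4 is expected to be small, in either direction, and most likely not beyond the scatter; the estimated step is a 1.3-fold lower number from compound 1 to compound 4 (0.12 log units; within the scatter). Compound 4 is therefore expected to give about 6500 nM, within a range from 2500 nM to 20000 nM.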

Compound 4, half-maximal inhibitory concentration in the CCRF-CEM assay: 8180 nM
Compound 4: middle estimate off by 1.3-fold (0.10 log units), on the low side; low and high end bracket the measured number.
By their numbers in the CCRF-CEM assay, from the lowest: compound 2; then compounds 4 and 1 (each within the scatter of the next); then compound 3.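

Among these compounds, compounds 1 and 4 form the first pair here that differs in one place only, so the effect of a single exchange can now be read directly. In the CCRF-CEM assay, going from 4-methylphenyl to 4-chlorophenyl gives a 1.0-fold lower number from compound 1 to compound 4 (0.02 log units; within the scatter), so at this spot on the aromatic ring, para to a large group, methyl and chloro cannot be told apart in cytotoxicity. In a physicochemical assay for lipophilicity (on this read-out higher numbers stand for higher lipophilicity and lower numbers for lower lipophilicity), compound 1 gives 5.08 and compound 4 gives 5.08, so the pair also matches on lipophilicity, and no information is available here to explain either match.

Among the compounds shown here, this single pair covers only two small groups, so it remains open whether an amine, a carboxylic acid or a longer chain at the same spot would also leave the number in the cytotoxicity assay in place or would move it beyond the scatter. On these data alone, it also remains open whether chloro in place of methyl would read the same way on a different core.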